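The source may report more compounds than this note shows. Statements on the series, on what has been measured and on what is new or still open speak of the compounds shown alone.

Working notes on the series in an assay on CHO-K1 cells for binding affinity to muscarinic acetylcholine receptor M5 (Homo sapiens); on this read-out lower numbers stand for stronger inhibition and higher numbers for weaker inhibition.

Three compounds carry numbers. Compound 1, `CC(C1=C(CCN(C)C)Cc2ccc(F)cc21)c1ccccn1`, gives 1050 nM in this assay. Compound 2, `CC(C1=C(CCN2CCCC2)Cc2ccccc21)c1ccccn1`, gives 2000 nM in this assay. Compound 3, `CCCC(C1=C(CCN(C)C)Cc2ccccc21)c1ccccn1`, gives 302 nM in this assay, the lowest of the three; compound 1 sits nearest to it and compound 2 furthest, both gaps lying beyond the usual scatter. Among the compounds with values here, compound 1 and compound 3 differ from each other in more than one place, so no single step between measured compounds is available.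

The next compound, compound 4, `CN(C)CCC1=C(Cc2ccccn2)c2ccccc2C1`, differs from compound 3 in one place: hydrogen in place of propyl on a saturated chain carbon bound to an aromatic carbon and a double-bonded ring carbon. Within the data shown here, no measured pair isolates this kind of change. Compound 3, which carries the propyl, holds the lowest number, and the methyl-bearing compound 1 and compound 2 sit higher, but both also differ elsewhere, so the weight of the chain alone is not shown. The working expectation is a move toward a higher number, of moderate size, for compound 4 in this assay: the step from compound 3 to compound 4 is estimated at a 3.3-fold higher number from compound 3 to compound 4 (0.52 log units; beyond the scatter). Compound 4 is therefore expected to give about 1000 nM in this assay, within a range of 300 nM to 3500 nM.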

Compound 4, inhibition constant: 3630 nM
Estimate against measurement, compound 4: 3.6-fold (0.56 log units) below, and the stated range ends below it.
By their numbers in this assay, from the lowest: compound 3; then compounds 1, 2 and 4 (each within the scatter of the next, the first and the last beyond it).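

Within the data shown here, this is the first single-place step: in this assay, hydrogen in place of propyl on a saturated chain carbon bound to an aromatic carbon and a double-bonded ring carbon gives a 12-fold higher number from compound 3 to compound 4 (1.08 log units; beyond the scatter), a large step beyond the scatter. Among these compounds, the group at this carbon therefore has a clear bearing on the number, which the earlier compounds could not show, as each of them also differs elsewhere. The comparison rests on a single pair and covers only the loss of the whole propyl group, on the core of compound 3.

As far as these compounds go, how a butyl group or a longer chain would read at this carbon, and where a methyl or an ethyl group would fall on this same core, stays open. Nothing at hand gives a reason for the size of the step.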